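The source may report more compounds than this note shows. Statements on the series, on what has been measured and on what is new or still open speak of the compounds shown alone.

In a functional assay on A-375 cells (Homo sapiens) for inhibition, read by CCK-8 assay, with a stated time of 72 h, tested at 2 uM (on this read-out lower numbers stand for less inhibition of growth and higher numbers for more inhibition of growth at the one concentration tested), compound 1 `COc1ccc(SCc2ccc(C(=O)Nc3ccccc3N)cc2)cc1` gives 10.2%, compound 2 `CC(C)(C)c1ccc(SCc2ccc(C(=O)Nc3ccccc3N)cc2)cc1` gives 2.13% and compound 3 `Nc1ccccc1NC(=O)c1ccc(CSc2ccc(F)cc2)cc1` gives 19.4%. Of these, only compound 2 lies beyond the scatter from compound 3. Compound 4 `Nc1ccccc1NC(=O)c1ccc(CSc2ccc(Cl)cc2)cc1` alters compound 3 at one place, with chloro in place of fluoro on an aromatic carbon. Two measured swaps at that same carbon bear on this change, and they are a number 9.2 percentage points higher from compound 1 to compound 3 (within the scatter) and, more clearly, a number 17.3 percentage points higher from compound 2 to compound 3 (beyond the scatter). Among the compounds with values here, neither swap involves chloro, and no chloro compound has been measured yet. The estimated change is small, namely a number 4.4 percentage points lower from compound 3 to compound 4 (within the scatter). Compound 4 is expected at 15%, with an estimated range from 4% to 30%.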

Compound 4, percent growth inhibition at one concentration: 25.3%
Beside the measured number, compound 4's estimate is 10.3 percentage points below it, within the range that was stated.
By their numbers in this assay, from the lowest: compounds 2, 1, 3 and 4 (each within the scatter of the next, the first and the last beyond it).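

At this carbon, para to a large group, in this assay the change from fluoro to chloro gives a number 5.9 percentage points higher from compound 3 to compound 4 (within the scatter) and so does not separate the two groups. Chloro also stands clear of both other groups, with a number 23.2 percentage points higher from compound 2 to compound 4 (beyond the scatter) and a number 15.1 percentage points higher from compound 1 to compound 4 (beyond the scatter) at this same carbon, whereas fluoro stood clear only of tert-butyl. Nothing available explains these differences. From the compounds shown here alone, whether a bromo, nitrile or amino group at this carbon would match chloro remains open. So does whether replacing the sulfur link would change these numbers.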